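A hydroxy added to compound 2

A few compounds are considered here, and "the series" means these few. Any claim that something is new, unique, unknown or untested is made for them only; others in the source may bear on it.

Compound 1 `CN(C)c1ccc2[nH]c(Cl)c(/C=C3/C(=O)Nc4ccc(O)cc43)c2c1`: 25700 nM
Compound 2 `COc1cc2c(/C=C3/C(=O)N(C)c4ccccc43)c[nH]c2cc1C`: 74100 nM

In a functional assay on cells (Melanoma cell, Homo sapiens) for inhibition, with a stated time of 48 h (on this read-out higher numbers stand for weaker inhibition of growth and lower numbers for stronger inhibition of growth), compound 2 gives 74100 nM, the higher of the two numbers, and compound 1 lies lower at 25700 nM, a gap beyond the scatter. Compound 3 `COc1cc2c(/C=C3/C(=O)N(C)c4ccc(O)cc43)c[nH]c2cc1C` differs from compound 2 by hydroxy in place of hydrogen on an aromatic carbon. Among the measured compounds shown here, no measured step shows this change alone. Compound 1, which also carries a hydroxy but differs elsewhere too, gives 25700 nM, so a small step towards stronger inhibition, near the scatter, is expected. The expected change is a 1.9-fold lower number from compound 2 to compound 3 (0.27 log units; within the scatter). The estimate for compound 3 is 40000 nM, with an expected range of 15000 nM to 90000 nM.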

Compound 3, concentration for total growth inhibition: 15100 nM
For compound 3 the middle estimate is 2.6-fold (0.42 log units) above the measured one; the measured number falls inside the stated range.
By their numbers in this assay, from the lowest: compounds 3 and 1 (each within the scatter of the next); then compound 2.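

In this assay, hydroxy in place of hydrogen on this aromatic carbon, meta to a fused ring and para to a fused ring, gives a 4.9-fold lower number from compound 2 to compound 3 (0.69 log units; beyond the scatter), a step beyond the scatter. This isolates the change at this position, which compound 1, with its hydroxy and other differences, could not do. No measurement shown explains the step. The compounds shown leave open whether a carboxylic acid or an amine on the same carbon would give a similar step, and whether the hydroxy itself is required there.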